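The source may report more compounds than this note shows. Statements on the series, on what has been measured and on what is new or still open speak of the compounds shown alone.

Working notes on the series. In an assay on isolated protein for inhibition of DNA topoisomerase 1 (Homo sapiens), with a stated time of 15 min (on this read-out higher numbers stand for weaker inhibition and lower numbers for stronger inhibition), compound 1 `NC[C@@H]1CCN(c2cc3c(cc2F)c(=O)c(C(=O)O)cn3Cc2ccc(-n3cccn3)cc2)C1` gives 91600 nM; compound 2 `COc1c(N2CC[C@@H](CN)C2)c(F)cc2c(=O)c(C(=O)O)cn(Cc3ccc(-c4ccc(F)cc4)cc3)c12` gives 60900 nM; compound 3 `NC[C@@H]1CCN(c2cc3c(cc2F)c(=O)c(C(=O)O)cn3Cc2ccc(-c3ccccc3)cc2)C1` gives 15600 nM, the lowest of the three numbers, clear of both others beyond the scatter. Among the compounds with values here, the only single-place step measured so far, a 5.9-fold lower number from compound 1 to compound 3 (0.77 log units; beyond the scatter), is modest. Compound 4 `NC[C@@H]1CCN(c2cc3c(cc2F)c(=O)c(C(=O)O)cn3Cc2ccc(-c3ccc(F)cc3)cc2)C1` differs from compound 3 by fluoro in place of hydrogen on an aromatic carbon. Within the data shown here, no measured step covers this change. Compound 2, which also carries a 4-fluorophenyl, differs from compound 3 in more than one place, and its number is higher than that of compound 3. For this assay a step within the scatter is therefore expected, a 1.2-fold lower number from compound 3 to compound 4 (0.08 log units; within the scatter). Compound 4 is estimated at 13000 nM, with a range from 6000 nM to 30000 nM.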

Compound 4, half-maximal inhibitory concentration: 69600 nM
Estimate against measurement, compound 4: 5.4-fold (0.73 log units) below; the measured number lies above the stated range.
By their numbers in this assay, from the lowest: compound 3; then compounds 2, 4 and 1 (each within the scatter of the next).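

In this assay, fluoro in place of hydrogen, para to a large group, gives a 4.5-fold higher number from compound 3 to compound 4 (0.65 log units; beyond the scatter) and so shows that this position responds to 1 added heavy atom. The step of a 1.1-fold higher number from compound 2 to compound 4 (0.06 log units; within the scatter) shows no effect of methoxy against hydrogen with the 4-fluorophenyl in place, and a 1.3-fold lower number from compound 1 to compound 4 (0.12 log units; within the scatter) separates 4-fluorophenyl from 1H-pyrazol-1-yl by no more than the scatter, leaving the unsubstituted phenyl of compound 3 alone at the low end. Nothing at hand accounts for the step from hydrogen to fluoro. Open, as far as these compounds go, is whether chloro or methyl on this carbon follows fluoro, and whether methoxy on the core of compound 3 would matter more than it does alongside 4-fluorophenyl.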